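Acyl variation at the ring amide nitrogen in this series

The source may report more compounds than this note shows. Statements on the series, on what has been measured and on what is new or still open speak of the compounds shown alone.

Measured so far:
compound 1 `CCOC(=O)/C=C/C(=O)N(CC(N)=O)NC(=O)[C@@H]1CCCN1C(C)=O`: 8.3 nM
compound 2 `CCOC(=O)/C=C/C(=O)N(CC(N)=O)NC(=O)[C@@H]1CCCN1C(=O)C1(NC(C)=O)CC1`: 9.3 nM

In an assay on isolated protein for inhibition of legumain (Mus musculus), read by fluorescence, with stated times of 30 s and 2.5 h (a lower number here means a stronger inhibitor, a higher number a weaker inhibitor), compound 1 gives 8.3 nM and compound 2 gives 9.3 nM. Compound 2 holds the higher of the two numbers, though a 1.1-fold higher number from compound 1 to compound 2 (0.05 log units; within the scatter). Compound 3 `CCOC(=O)/C=C/C(=O)N(CC(N)=O)NC(=O)[C@@H]1CCCN1C(=O)c1ccc(CNC(C)=O)cc1` carries 4-(acetamidomethyl)phenyl in place of 1-acetamidocyclopropyl on a carbonyl carbon. Going by the values given here, the only step at this carbonyl carbon is the one from compound 1 to compound 2, and it stayed within the scatter, so no shift beyond the scatter is expected in this assay for compound 3. The expected step is a 1.1-fold higher number from compound 2 to compound 3 (0.03 log units; within the scatter). Compound 3 is therefore estimated at 10 nM, with a range from 4 nM to 25 nM.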

Compound 3, half-maximal inhibitory concentration: 267 nM
The estimate for compound 3 lay 27-fold (1.43 log units) below the measured number, outside the stated range (above it).
By their numbers in this assay, from the lowest: compounds 1 and 2 (each within the scatter of the next); then compound 3.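

With 4-(acetamidomethyl)phenyl on the carbonyl carbon, this position proves sensitive to the acyl group: the change gives a 29-fold higher number from compound 2 to compound 3 (1.46 log units; beyond the scatter) and a 32-fold higher number from compound 1 to compound 3 (1.51 log units; beyond the scatter) as well. The agreement within the scatter between methyl and 1-acetamidocyclopropyl therefore does not extend to every acyl group here, even though compound 2 and compound 3 both carry an acetamide.

Still open, going by these compounds, is whether the phenyl ring alone or its acetamidomethyl arm tracks with the loss; unsubstituted phenyl, or phenyl bearing an amine or a carboxylic acid, would separate these. No supporting data explain the size of this step.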